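Swapping the saturated ring on the amine of compound 2

The source may report more compounds than this note shows. Statements on the series, on what has been measured and on what is new or still open speak of the compounds shown alone.

Measured compounds:
- compound 1, `N#Cc1cnc(NCc2cnccc2C(F)(F)F)cc1NC[C@H]1CC[C@H](O)CC1`: 2000 nM
- compound 2, `N#Cc1cnc(NCc2cnccc2C(F)(F)F)cc1NC1CCOCC1`: 9800 nM
- compound 3, `N#Cc1cnc(NCc2cncnc2OCC(F)F)cc1N[C@H]1CC[C@@H](O)CC1`: 90 nM

All three share one core and were tested in an assay on isolated protein for inhibition of protein kinase C delta type (Homo sapiens), read by TR-FRET, with a stated time of 2 h; on this read-out lower numbers stand for stronger inhibition and higher numbers for weaker inhibition. Compound 2 stands at the weak end of the set: its number is the highest of the three, and both other compounds lie beyond the scatter below it, compound 1 nearest and compound 3 furthest.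

The new compound 4, `CC1(C)[C@@H](Nc2cc(NCc3cnccc3C(F)(F)F)ncc2C#N)C[C@H]1C(N)=O`, is made from compound 2 by one change: 3-carbamoyl-2,2-dimethylcyclobutyl in place of oxan-4-yl on a nitrogen on an aromatic ring.

For the measured compounds named here, only one measured step touches this position. From compound 1 to compound 2 the number rose, a 4.9-fold higher number from compound 1 to compound 2 (0.69 log units; beyond the scatter), when a group carrying a hydrogen-bond donor gave way to oxan-4-yl, which carries none. The entering 3-carbamoyl-2,2-dimethylcyclobutyl again brings one hydrogen-bond donor, so the step from compound 2 to compound 4 is expected to run the other way, toward a lower number, by a size similar to that step, a 5.4-fold lower number from compound 2 to compound 4 (0.74 log units; beyond the scatter). Compound 3 differs in two places and cannot be read as a direct guide.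

For compound 4 in this assay, the estimated value is 1800 nM, within 450 nM to 7000 nM.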

Compound 4, half-maximal inhibitory concentration: 4500 nM
Beside the measured number, compound 4's estimate is 2.5-fold (0.40 log units) below it; the measured number falls inside the stated range.
By their numbers in this assay, from the lowest: compound 3; then compound 1; then compound 4; then compound 2.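

In this assay, putting 3-carbamoyl-2,2-dimethylcyclobutyl in place of oxan-4-yl on a nitrogen on an aromatic ring gives a 2.2-fold lower number from compound 2 to compound 4 (0.34 log units; beyond the scatter), so a second group carrying a hydrogen-bond donor also sits on the lower side of compound 2, although this step is a modest one. The two groups with a donor are not equal, however: there is a 2.3-fold higher number from compound 1 to compound 4 (0.35 log units; beyond the scatter), which shows that the presence of a donor does not alone set the number at this position, and that the (4-hydroxycyclohexyl)methyl group remains the better of the two on this shared core. Nothing available here explains either step, or says which feature of the groups is responsible.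

The entering group differs from oxan-4-yl in its ring size, its two methyl groups and its carbamoyl group all at once, so these three changes cannot be told apart from the compounds shown. A plain cyclobutyl group, a cyclobutyl group without the two methyl groups, or a carboxylic acid in place of the carbamoyl group on the same ring would each separate one of these features from the others.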